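The source may report more compounds than this note shows. Statements on the series, on what has been measured and on what is new or still open speak of the compounds shown alone.

Of the compounds shown here, three built on one shared core have been measured in a functional assay on A549 cells (Homo sapiens) for antiproliferative activity, read by MTT assay, with a stated time of 24 h; on this read-out higher numbers stand for weaker inhibition and lower numbers for stronger inhibition. Compound 1 `O=C(NNc1cccc(Cl)c1)c1ccc(NS(=O)(=O)c2cnc(O)nc2O)cc1` gives 7290 nM in this assay. Compound 2 `O=C(NNc1ccccc1F)c1ccc(NS(=O)(=O)c2cnc(O)nc2O)cc1` gives 11700 nM. Among the compounds with values here, the only step between two compounds that differ in a single place, a 1.6-fold higher number from compound 1 to compound 2 (0.21 log units; within the scatter), stays within the scatter. Compound 3 `Cc1cccc(NNC(=O)c2cccc(NS(=O)(=O)c3cnc(O)nc3O)c2)c1` returns only a limit of the assay, > 20000 nM, and not a number. Compound 3 therefore stands at the limit of > 20000 nM in this assay, at which 1 of the 3 values shown sits, and nothing more than that can be read from its result.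

Compound 4 `O=C(NNC(=O)c1ccccc1F)c1cccc(NS(=O)(=O)c2cnc(O)nc2O)c1` has not yet been measured. It differs from compound 3 by (2-fluorophenyl)carbonyl in place of 3-methylphenyl on an amine nitrogen. Within the data shown here, no measured step bears on this change: the single step recorded, between compound 1 and compound 2, exchanges 2-fluorophenyl for 3-chlorophenyl without bringing in a carbonyl, and it stayed within the scatter. Since compound 3 gives only a limit, no direction for the step can be read from the numbers. Compound 4 is expected to stay near that limit, with a step that the limit leaves unreadable from compound 3 to compound 4 as the estimated step. The estimate for compound 4 in this assay is 25000 nM, with a range from 8000 nM to 80000 nM, and a real chance that only a limit is reported again.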

Compound 4, half-maximal inhibitory concentration: 10800 nM
The estimate for compound 4 lay 2.3-fold (0.36 log units) above the measured number, within the range that was stated.
By their numbers in this assay, from the lowest: compounds 1, 4 and 2 (each within the scatter of the next). At a limit, above all of these: compound 3.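

In this assay compound 4 gives 10800 nM, the first number shown for a group carrying a carbonyl on this amine nitrogen, whose other neighbour is an amide-type nitrogen. From the compounds shown here alone, putting (2-fluorophenyl)carbonyl in place of 3-methylphenyl here gives an at least 1.8-fold lower number from compound 3 to compound 4 (0.26 log units; that floor lies within the scatter), so the data show a measurable result for the new group, but the true size of the change remains unknown and may be small or large. Compound 3 gives only a limit of the assay and not a number: the limit of > 20000 nM in this assay, at which 1 of the 4 values shown sits.

What the compounds shown leave open is which part of the new group matters at this nitrogen, the carbonyl or the fluorine on the ring, since the two enter together in a single change. A plain benzoyl group without the fluorine would separate those two parts, and an acetyl group in the same place would show whether the aromatic ring in the entering group is needed at all to give a number in this assay.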